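Pyridin-4-yl in place of bromo at two positions

The source may report more compounds than this note shows. Statements on the series, on what has been measured and on what is new or still open speak of the compounds shown alone.

Measured so far, in a functional assay on HL-60 cells (Homo sapiens) for cytotoxicity, read by luminescence and CellTiter-Glo, with a stated time of 3 days; on this read-out lower numbers stand for stronger inhibition and higher numbers for weaker inhibition:
compound 1, `N#Cc1ccc(NC(=O)c2cc(-c3ccncc3)ccc2O)cc1`, gives 5410 nM
compound 2, `N#Cc1ccc(NC(=O)c2cc(Br)ccc2O)cc1`, gives 620 nM
compound 3, `N#Cc1ccc(NC(=O)c2ccc(Br)cc2O)cc1`, gives 1210 nM

Compound 2 and compound 3 share the same atoms joined differently; the difference between the two cores is not broken down here. Their values in this assay lie within the scatter of each other, so no order between them is claimed.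

Compound 1 carries the change pyridin-4-yl in place of bromo on an aromatic carbon relative to compound 2, and the step is an 8.7-fold higher number from compound 2 to compound 1 (0.94 log units; beyond the scatter).

Compound 4, `N#Cc1ccc(NC(=O)c2ccc(-c3ccncc3)cc2O)cc1`, not yet measured in this assay, carries the change pyridin-4-yl in place of bromo on an aromatic carbon relative to compound 3. The two "place" descriptions are not the same word for word: in compound 1 the entering group stands meta to a large group and para to a hydroxy group, whereas in compound 4 it stands meta to a hydroxy group and para to a large group. The change is therefore the same kind of change, not the same.

Going by the values given here, only one earlier instance of this kind of change exists here, so the expectation rests on it alone. For compound 4 the step expected is an 8.3-fold higher number from compound 3 to compound 4 (0.92 log units; beyond the scatter), because compound 2 to compound 1 showed an 8.7-fold higher number from compound 2 to compound 1 (0.94 log units; beyond the scatter). Compound 4 is accordingly estimated at 10000 nM in this assay, with a range from 3000 nM to 35000 nM reflecting that the position differs from the measured case.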

Compound 4, half-maximal inhibitory concentration: 7090 nM
Beside the measured number, compound 4's estimate is 1.4-fold (0.15 log units) above it; low and high end bracket the measured number.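

In this assay, pyridin-4-yl in place of bromo on an aromatic carbon gives a 5.9-fold higher number from compound 3 to compound 4 (0.77 log units; beyond the scatter) on the second core. The change therefore carries over between these two cores, with the same direction and a similar size of step: the same change on two cores in this assay, an 8.7-fold higher number (0.94 log units; beyond the scatter) from compound 2 to compound 1 and a 5.9-fold higher number (0.77 log units; beyond the scatter) from compound 3 to compound 4, 1.5-fold (0.17 log units) apart, within the scatter of two such steps

This agreement holds even though the entering group stands para to a hydroxy group in compound 1 and meta to a hydroxy group in compound 4. Going by these compounds alone, it rests on only two pairs, one leaving group, one entering group and one cell read-out, so it does not show that the step would hold on any other core or with any other group, and it does not explain why the number rises.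

The compounds shown leave open whether the step follows from the ring nitrogen of pyridin-4-yl or from any six-membered aromatic ring at these places, a question that a phenyl group in place of bromo would address. Going by these compounds, all four compounds also keep the nitrile and the hydroxy group, so it remains open how the same change behaves with a carboxylic acid in place of the nitrile or an amine in place of the hydroxy group.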